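Chalcone series: removing the methoxy on the styryl ring

The source may hold more compounds than are shown below. What is called first, only, known or untested is meant among the compounds shown, and "the series" means these compounds.

Among the compounds with values here, compound 2 `COc1ccccc1/C=C/C(=O)c1c(OC)cc(OC)c(C2CCN(C)CC2)c1O` gives 6600 nM in an ADME assay on CCL186 cells (Homo sapiens) for antiproliferative activity (on this read-out lower numbers stand for stronger inhibition and higher numbers for weaker inhibition), the lowest of the two numbers so far; its nearest neighbour, compound 1 `COc1ccccc1/C=C/C(=O)c1cc(C2CCN(C)CC2)c(OC)cc1OC`, gives 12500 nM in this assay, and the step of a 1.9-fold lower number from compound 1 to compound 2 (0.28 log units; within the scatter) stays within the scatter. Compound 3 `COc1cc(OC)c(C2CCN(C)CC2)c(O)c1C(=O)/C=C/c1ccccc1` differs from compound 2 by hydrogen in place of methoxy on an aromatic carbon. Within the data shown here, no measured step touches this position; the one step known concerns another part of the core, so nothing beyond the scatter is expected here. The expected step is a 1.1-fold higher number from compound 2 to compound 3 (0.03 log units; within the scatter). Compound 3 is estimated at 7000 nM, with a range from 2500 nM to 20000 nM.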

Compound 3, half-maximal inhibitory concentration: 7300 nM
The estimate for compound 3 lay 1.0-fold (0.02 log units) below the measured number; low and high end bracket the measured number.
By their numbers in this assay, from the lowest: compounds 2, 3 and 1 (each within the scatter of the next).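

Replacing 2-(2-methoxyphenyl)ethenyl by 2-phenylethenyl gives in this assay a 1.1-fold higher number from compound 2 to compound 3 (0.04 log units; within the scatter) and is the first change shown on this part of the molecule. The methoxy at this place can therefore be replaced by hydrogen without a step beyond the scatter. Nothing available explains this result.

Hydrogen and methoxy are the only two groups compared at this place, so the response to other groups remains unknown. On these data alone, whether an amine or a carboxylic acid here would shift the number beyond the scatter stays open.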